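Removing a Phenolic Hydroxy Next to a Carboxylic Acid

The source may hold more compounds than are shown below. What is called first, only, known or untested is meant among the compounds shown, and "the series" means these compounds.

Four compounds are compared here, each carrying a carboxy group on a six-membered aromatic ring. Compound 1 `O=C(O)c1cc(-n2cccc2)ccc1O` was tested in an ADME assay on MT2 cells (Homo sapiens) for cytotoxicity, read by XTT assay, with a stated time of 4 days (a higher number here means that more compound is tolerated, a lower number that less compound is tolerated), and gave 493000 nM. Compound 3 `O=C(O)c1cccc(-n2cccc2)c1` is its close relative; in this assay compound 3 gave 302000 nM. The change between them is hydrogen in place of hydroxy on an aromatic carbon, and in this assay it produced a 1.6-fold lower number from compound 1 to compound 3 (0.21 log units; within the scatter).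

Compound 2 `O=C(O)c1ccc(N2C(=O)C=CC2=O)cc1O` carries a different substituent on the shared core; how its core differs from that of compound 1 is not broken down here. In this assay compound 2 gave only a limit, > 400000 nM, which is the limit of > 400000 nM in this assay, at which 1 of the 3 values shown sits.

Compound 4 `O=C(O)c1ccc(N2C(=O)C=CC2=O)cc1` is not yet measured. It relates to compound 2 through (hydrogen in place of hydroxy on an aromatic carbon). This is the same kind of change as that from compound 1 to compound 3, though the surroundings differ: in compound 1 the hydroxy sat para to a 1H-pyrrol-1-yl group (5 heavy atoms), whereas in compound 2 it sits meta to a group of 7 heavy atoms. From compound 2 to compound 4 the expected step is an at least 1.1-fold lower number from compound 2 to compound 4 (0.05 log units; that floor lies within the scatter), resting on the small step of a 1.6-fold lower number from compound 1 to compound 3 (0.21 log units; within the scatter). Compound 4 is therefore estimated at 350000 nM in this assay, somewhere between 150000 nM and 800000 nM, and it may well again come out as only a limit.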

Compound 4, half-maximal cytotoxic concentration: > 400000 nM
Compound 4 was reported as a limit (the forecaster's own chance of this, stated with the estimate: 50%); at least 1.1-fold (0.05 log units) between middle value and limit.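

Compound 2 and compound 4 both came out as limits in this assay, so no step can be read between them: the limit of > 400000 nM in this assay, at which 2 of the 4 values shown sit. The compounds shown leave open whether hydrogen in place of hydroxy on an aromatic carbon changes the tolerated concentration at all in this pair.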